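A few compounds are considered here, and "the series" means these few. Any claim that something is new, unique, unknown or untested is made for them only; others in the source may bear on it.

Measured in a functional assay on MCF7 cells (Homo sapiens) for antiproliferative activity, read by MTT assay; on this read-out lower numbers stand for stronger inhibition and higher numbers for weaker inhibition:
- compound 1 `Cc1c(-n2cc(COc3ccc(/C=C/C(=O)c4cc5c(cc4O)OC(C)(C)CC5)cc3)nn2)cccc1[N+](=O)[O-]`: 176000 nM
- compound 2 `COc1ccc(-n2cc(COc3ccc(/C=C/C(=O)c4cc5c(cc4O)OC(C)(C)CC5)cc3)nn2)c([N+](=O)[O-])c1`: "not active" (no number reported)
- compound 3 `CC1(C)CCc2c(ccc(C(=O)/C=C/c3ccc(OCc4cn(-c5ccc(Br)cc5)nn4)cc3)c2O)O1`: "not active" (no number reported)

Compound 3 has no single number on this read-out. It is reported as "not active" (no number reported), and compound 2 is the only other entry without a number, also reported as "not active" (no number reported). Compound 1 alone gives a number, 176000 nM, so compound 3 can only be placed among the inactive entries of a small set.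

The next compound is compound 4 `CCCCCn1cc(COc2ccc(/C=C/C(=O)c3ccc4c(c3O)CCC(C)(C)O4)cc2)nn1`, with pentyl in place of 4-bromophenyl on an aromatic nitrogen. All three measured compounds carry a substituted aromatic ring at this place, and none carries an open chain, so the data give no direct guide to this change.

For the measured compounds named here, with no number for compound 3, no step from it can be sized. In this assay, a small step towards stronger inhibition is expected, at most enough to yield a weak but measurable value. Going by the values given here, the only numerical reference is compound 1 at 176000 nM, and a further report without a number would not be surprising. For compound 4, the expected value is about 100000 nM, with an estimated range of 30000 nM to 250000 nM.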

Compound 4, half-maximal inhibitory concentration: 191000 nM
Beside the measured number, compound 4's estimate is 1.9-fold (0.28 log units) below it; low and high end bracket the measured number.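

No step can be read from compound 3 to compound 4: compound 3 is reported as "not active" without a number, so the change from 4-bromophenyl to pentyl cannot be sized. No measured evidence bears on this result. In this assay the compounds shown leave open how an open chain compares with an aromatic ring at this place on a matched core.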